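The source may hold more compounds than are shown below. What is called first, only, known or untested is meant among the compounds shown, and "the series" means these compounds.

Measured so far:
compound 1 `O=C(/C=C/c1ccc([N+](=O)[O-])o1)c1ccc(F)cc1`: in a toxicity assay on Vero cells (Chlorocebus sabaeus) for cytotoxicity (on this read-out lower numbers stand for higher toxicity in this test and higher numbers for lower toxicity in this test), compound 1 gives 463000 nM
compound 2 `COc1ccc(C(=O)/C=C/c2ccc([N+](=O)[O-])o2)cc1`: in this assay compound 2 gives 571000 nM

Compound 1 holds the lowest of the two numbers in this assay; its nearest neighbour is compound 2, and the step of a 1.2-fold higher number from compound 1 to compound 2 (0.09 log units; within the scatter) stays within the scatter, so the two compounds cannot be told apart on this read-out. The unmeasured compound 3 `O=C(/C=C/c1ccc([N+](=O)[O-])o1)c1ccc(OCc2cccc(Cl)c2)cc1` differs from compound 1 in one place: (3-chlorobenzyl)oxy in place of fluoro on an aromatic carbon. For the measured compounds named here, the only measured step at this carbon, a 1.2-fold higher number from compound 1 to compound 2 (0.09 log units; within the scatter), was within the scatter. Going by the values given here, no measured compound carries a group of this size at that carbon, so the expectation rests on that single step alone and is held loosely. For compound 3 no step beyond the scatter in this assay is expected, a 1.5-fold lower number from compound 1 to compound 3 (0.19 log units; within the scatter). Compound 3 is therefore estimated at 300000 nM, with a range from 80000 nM to 900000 nM.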

Compound 3, half-maximal cytotoxic concentration: 307000 nM
For compound 3 the middle estimate is 1.0-fold (0.01 log units) below the measured one, and the stated range covers the measured number.
By their numbers in this assay, from the lowest: compounds 3, 1 and 2 (each within the scatter of the next).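

The step of a 1.5-fold lower number from compound 1 to compound 3 (0.18 log units; within the scatter) shows that in this assay this aromatic carbon can carry (3-chlorobenzyl)oxy, with its additional six-membered aromatic ring of carbon only, and compound 3 still cannot be told apart from compound 1. Set against the smaller methoxy group, adding 3-chlorophenyl on the saturated chain carbon gives a 1.9-fold lower number from compound 2 to compound 3 (0.27 log units; within the scatter), so this comparison also gives no readable difference. Across methoxy, fluoro and (3-chlorobenzyl)oxy, the read-out therefore shows no dependence on the group at this carbon, and no supporting data bear on the reason for this.

From the compounds shown here alone, whether an amine or a carboxylic acid at this carbon would produce a step beyond the scatter remains open. Going by these compounds, the effect of a longer chain between the oxygen and the aromatic ring, or of a change elsewhere on the shared core, also remains open.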